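Benzyl Ether Series: Replacing the Phenyl with Hexyl

The compounds below may be only part of what the source reports. "The series", "measured", "known", "first", "only" and "open" are said of these compounds alone.

Three compounds share a common core and differ only in the group on the ether carbon. Compound 1 `O=[N+]([O-])c1cccc(COCNc2n[n+]([O-])c3ccccc3[n+]2[O-])c1` gives 16600 nM in a functional assay on KB cells (Homo sapiens) for cytotoxicity, read by MTT assay, with a stated time of 72 h; a higher number here means a weaker inhibitor, a lower number a stronger inhibitor. Compound 2 `[O-][n+]1nc(NCOCc2ccccc2)[n+]([O-])c2ccccc21` gives 12300 nM, and compound 3 `CC(OCNc1n[n+]([O-])c2ccccc2[n+]1[O-])c1ccccc1` gives 14000 nM. Compound 2 has the smallest number of the three, but neither compound 1 nor compound 3 is separated from it beyond the scatter: a 1.3-fold lower number from compound 1 to compound 2 (0.13 log units; within the scatter), and a 1.1-fold higher number from compound 2 to compound 3 (0.06 log units; within the scatter).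

Compound 4 `CCCCCCCOCNc1n[n+]([O-])c2ccccc2[n+]1[O-]` is not yet measured. Relative to compound 2 the change is hexyl in place of phenyl on a saturated chain carbon bound to an oxygen on a saturated carbon. Both measured steps alter the same region of the molecule, a substituent on the aromatic ring in one case and on the ether carbon in the other, and both stayed within the scatter. Within the data shown here, no measured step removes the ring itself, so the expectation rests on those two small steps only: no change beyond the scatter is expected. Compound 4 is expected to give about 14000 nM, within 5000 nM to 40000 nM. The expected step is a 1.1-fold higher number from compound 2 to compound 4 (0.06 log units; within the scatter).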

Compound 4, half-maximal inhibitory concentration: 14000 nM
Compound 4: the middle estimate sits on the measured number at the digits printed, within the range that was stated.
By their numbers in this assay, from the lowest: compounds 2, 3, 4 and 1 (each within the scatter of the next).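

In this assay, among these compounds, the exchange of phenyl for hexyl is the first step here that removes the aromatic ring rather than altering a substituent, and it stays within the scatter (a 1.1-fold higher number from compound 2 to compound 4 (0.06 log units; within the scatter)). For this pair, on a saturated chain carbon bound to an oxygen on a saturated carbon, an open chain with no ring and the same count of heavy atoms reads the same as phenyl, so the ring is not needed to hold the number at this level. No measured information available here accounts for this match between the two groups.

Going by these compounds, whether a chain longer than hexyl, an amine or a carboxylic acid at this position would also stay within the scatter remains open. Every step shown lies within the scatter, so what kind of change here would move the number beyond it is unknown.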